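Dropping the chloro group from a pyridine substituent

The source may hold more compounds than are shown below. What is called first, only, known or untested is meant among the compounds shown, and "the series" means these compounds.

In a functional assay on MCF7 cells (Homo sapiens) for inhibition, read by CCK-8 assay, with a stated time of 48 h (on this read-out higher numbers stand for weaker inhibition of growth and lower numbers for stronger inhibition of growth), compound 1 `Cc1ccccc1Nc1nc(NC2CC2)ncc1Cl` gives > 100000 nM as a limit and not a number. In this assay compound 2 `Cc1ccccc1Nc1nc(Nc2ccccn2)ncc1Cl` gives a true number of 31400 nM and this marks an at least 3.1-fold lower number from compound 1 to compound 2 (0.50 log units; beyond the scatter) for pyridin-2-yl in place of cyclopropyl. In this assay compound 3 `Cc1ccccc1Nc1nc(Nc2cc(Cl)ccn2)ncc1Cl` gives > 100000 nM as a limit too, so its exact standing cannot be read.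

Compound 4 `Cc1ccccc1Nc1nc(NCc2ccncc2)ncc1Cl` brings this change: (pyridin-4-yl)methyl in place of 4-chloropyridin-2-yl on a nitrogen on an aromatic ring and the chloro group leaves with the old ring. The closest guide is an at least 3.1-fold higher number from compound 2 to compound 3 (0.50 log units; beyond the scatter) for chloro in place of hydrogen. Going by the values given here, compound 4 keeps a pyridine ring without chloro, as compound 2 does, though a methylene-linked (pyridin-4-yl)methyl has no measured step of its own. A modest move towards stronger inhibition is therefore expected, estimated as an at least 2.0-fold lower number from compound 3 to compound 4 (0.30 log units; that floor lies within the scatter) and uncertain in size. For compound 4 the expected value is 50000 nM with an estimated range from 20000 nM to 120000 nM in this weak region.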

Compound 4, concentration for 50% growth inhibition: > 100000 nM
Compound 4 was reported as a limit (the forecaster's own chance of this, stated with the estimate: 40%); middle value at least 2.0-fold (0.30 log units) away from the limit.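

In this assay, a pyridine ring free of chloro on this nitrogen is not enough to give a true number: (pyridin-4-yl)methyl in place of pyridin-2-yl gives an at least 3.1-fold higher number from compound 2 to compound 4 (0.50 log units; beyond the scatter). Among the four compounds, only compound 2 gives a true number, and compound 4 goes against any reading that leaving out the chloro group alone restores growth inhibition. The steps that link compound 4 to compound 1 and compound 3 cannot be read, because both ends of each step are limits and not numbers: the limit of > 100000 nM in this assay, at which 3 of the 4 values shown sit.

Still open, from the compounds shown here alone, is whether a pyridin-2-yl ring carrying an amine or a methoxy group instead of chloro would give a stronger value than compound 2. Also open, going by these compounds, is whether a longer chain between the nitrogen and the pyridine ring would give a true number.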